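Anilino to naphthylamino on a diterpenoid lactone core

A few compounds are considered here, and "the series" means these few. Any claim that something is new, unique, unknown or untested is made for them only; others in the source may bear on it.

Compound 1 `C=C1[C@@H](OC(C)=O)C[C@@H]2[C@](C)(CO[Si](C)(C)C(C)(C)C)[C@H](OC(C)=O)CC[C@@]2(C)[C@@H]1C[C@@H](Nc1ccccc1)C1=CCOC1=O` carries an anilino group on the carbon chain that joins the core to the butenolide. In a functional assay on A549 cells (Homo sapiens) for cytotoxicity, read by sulforhodamine B assay (a higher number here means a weaker inhibitor, a lower number a stronger inhibitor), compound 1 gives 4500 nM. Among the compounds with values here, its only measured companion is compound 2 `C=C1[C@@H](OC(C)=O)C[C@@H]2[C@](C)(COC=O)[C@H](OC(C)=O)CC[C@@]2(C)[C@@H]1C[C@@H](Nc1ccc(O)cc1)C1=CCOC1=O`, which bears a hydroxyphenyl on the same nitrogen and a formate in place of the silyl ether; in this assay compound 2 gives 29100 nM. Compound 1 therefore holds the lower of the two numbers, and the gap to compound 2 lies beyond the usual scatter, although the two structures differ in two places, so no single change can be credited.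

Compound 3 `C=C1[C@@H](OC(C)=O)C[C@@H]2[C@](C)(CO[Si](C)(C)C(C)(C)C)[C@H](OC(C)=O)CC[C@@]2(C)[C@@H]1C[C@@H](Nc1cccc2ccccc12)C1=CCOC1=O` has not yet been measured. It keeps the silyl ether and both acetates of compound 1 and differs only at the nitrogen: naphthalen-1-yl in place of phenyl on an amine nitrogen. Within the data shown here, no measured pair shows such a change alone. Because compound 1 stands at 4500 nM and the shared core is unchanged, a step of modest size at most is expected here, and the expected step from compound 1 to compound 3 is a 1.3-fold lower number from compound 1 to compound 3 (0.11 log units; within the scatter). Compound 3 is estimated to give 3500 nM in this assay, with a range from 1200 nM to 10000 nM.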

Compound 3, half-maximal inhibitory concentration: 4970 nM
Estimate against measurement, compound 3: 1.4-fold (0.15 log units) below; measured number inside the range.
By their numbers in this assay, from the lowest: compounds 1 and 3 (each within the scatter of the next); then compound 2.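

In this assay, within the data shown here, naphthalen-1-yl in place of phenyl on an amine nitrogen gives a 1.1-fold higher number from compound 1 to compound 3 (0.04 log units; within the scatter), and this is the first change that can be read alone. With the silyl ether and both acetates held fixed, going from one six-membered aromatic ring of carbon to 2 leaves the reading within the scatter, so this nitrogen accepts the larger aryl group with no measurable difference in this assay. Nothing measured here accounts for that outcome.

On these data alone, whether the same holds for other groups on this nitrogen, such as naphthalen-2-yl, benzyl or a saturated cyclohexyl, remains open, since the two aryl groups compared here say nothing about a group without an aromatic ring attached directly to the nitrogen. Also open, as far as these compounds go, is what the hydroxyphenyl and the formate each contribute on their own, and whether a free alcohol in place of the silyl ether would alter the reading when the anilino group stays in place.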